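Neopentyl in place of 3-methylphenyl on a slowly cleared core

The source may report more compounds than this note shows. Statements on the series, on what has been measured and on what is new or still open speak of the compounds shown alone.

compound 1 `Cc1cccc([C@@H](O)C(=O)N2N=CC[C@H]2C(=O)NCc2cc(Cl)ccc2-n2cnnn2)c1`: < 12 mL.min-1.g-1
compound 2 `CC1(C[C@@H](O)C(=O)N2C[C@H]3C[C@H]3[C@H]2C(=O)NCc2cc(Cl)ccc2-n2cnnn2)CC1`: 12 mL.min-1.g-1
compound 3 `CC(C)(C)[C@@H](O)C(=O)N1CC(=O)C[C@H]1C(=O)NCc1cc(Cl)ccc1-n1cnnn1`: < 12 mL.min-1.g-1

In an ADME assay on liver for metabolic stability, with Liver microsome (Homo sapiens) as the target, read by LC-MS, using microsomes (on this read-out higher numbers stand for fast clearance and lower numbers for slow clearance), compound 1 returns < 12 mL.min-1.g-1, which is a limit of the assay and not a number. Compound 3 likewise returns a limit, < 12 mL.min-1.g-1. Compound 2 gives 12 mL.min-1.g-1. Compound 1 therefore sits among the slowly cleared members of this set, at the limit of < 12 mL.min-1.g-1 in this assay, at which 2 of the 3 values shown sit. Compound 4 `CC(C)(C)C[C@@H](O)C(=O)N1N=CC[C@H]1C(=O)NCc1cc(Cl)ccc1-n1cnnn1` differs from compound 1 by neopentyl in place of 3-methylphenyl on a saturated chain carbon bound to a carbonyl carbon and an oxygen on a saturated carbon. Among the compounds with values here, no measured pair shows this exchange, so the step expected in this assay, a number no lower from compound 1 to compound 4 (the limit leaves the size open), is none beyond the scatter. Compound 4 is expected to give 12 mL.min-1.g-1, with a range from 6 mL.min-1.g-1 to 30 mL.min-1.g-1, and most likely another limit.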

Compound 4, intrinsic clearance in microsomes: 22 mL.min-1.g-1
Compound 4: the middle estimate sits 1.8-fold (0.26 log units) below what was measured; the measured number falls inside the stated range.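

In this assay, neopentyl in place of 3-methylphenyl gives an at least 1.8-fold higher number from compound 1 to compound 4 (0.26 log units; that floor lies within the scatter). On this core, a group with no ring at this position thus yields a readable number, with compound 4 at 22 mL.min-1.g-1. The real size of the step stays unknown, because compound 1 holds a limit and not a number: the limit of < 12 mL.min-1.g-1 in this assay, at which 2 of the 4 values shown sit.

As far as these compounds go, whether a cyclohexyl ring or a shorter chain such as isopropyl on this saturated chain carbon would give a number or another limit stays open. So does whether the same exchange acts alike on a different core.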